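Sulfur-linked groups on the carbonyl carbon of compound 1

A few compounds are considered here, and "the series" means these few. Any claim that something is new, unique, unknown or untested is made for them only; others in the source may bear on it.

In a functional assay on isolated protein for inhibition of Glucose-dependent insulinotropic receptor (Rattus norvegicus), read by HTRF and cAMP accumulation (a higher number here means a larger maximal response, a lower number a smaller maximal response), compound 1 `Cc1nc(S(C)(=O)=O)ccc1Oc1ncnc(OC2CCN(C(=O)OC(C)(C)C(F)(F)F)CC2)c1F` gives 79%, the second highest of the three numbers measured. Nearest is compound 3 `Cc1nc(S(C)(=O)=O)ccc1Oc1ncnc(OC2CCN(C(=O)SC(C)C)CC2)c1F`, which gives 81%; the step of a number 2 percentage points higher from compound 1 to compound 3 (within the scatter) lies within the scatter. Furthest is compound 2 `Cc1nc(S(C)(=O)=O)ccc1Oc1ncnc(OC2CCN(C(=O)OC3COC3)CC2)c1F`, which gives 66%, the step of a number 13 percentage points lower from compound 1 to compound 2 (beyond the scatter) being beyond the scatter.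

Compound 4 `Cc1nc(S(C)(=O)=O)ccc1Oc1ncnc(OC2CCN(C(=O)SC3CC3)CC2)c1F` differs from compound 1 in one place: a group of 4 heavy atoms (3 carbon, 1 sulfur; one three-membered non-aromatic ring of carbon only) in place of a group of 8 heavy atoms (4 carbon, 1 oxygen, 3 fluorine; no ring), on a carbonyl carbon. For the measured compounds named here, two measured steps bear on this. The step of a number 2 percentage points higher from compound 1 to compound 3 (within the scatter) also exchanges the oxygen-linked 1-methyl-1-(trifluoromethyl)ethoxy for a sulfur-linked isopropylsulfanyl on the carbonyl carbon and stays within the scatter, while the step of a number 15 percentage points higher from compound 2 to compound 3 (beyond the scatter) shows the sulfur-linked group reaching the higher of the two numbers against (oxetan-3-yl)oxy. Because of a number 2 percentage points higher from compound 1 to compound 3 (within the scatter), the step expected from compound 1 to compound 4 is a number 1 percentage points higher from compound 1 to compound 4 (within the scatter), that is none beyond the scatter. For compound 4 the estimate is 80%, with a range from 70% to 90%.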

Compound 4, largest response reached (reported as efficacy), in percent of the reference or control that the assay uses: 80%
Compound 4: the middle estimate sits on the measured number at the digits printed; the measured number falls inside the stated range.
By their numbers in this assay, from the lowest: compound 2; then compounds 1, 4 and 3 (each within the scatter of the next).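

In this assay, cyclopropyl in place of isopropyl on a sulfur gives a number 1 percentage points lower from compound 3 to compound 4 (within the scatter), so at this position the ring and the open branch cannot be told apart. The second sulfur-linked group gives a number 1 percentage points higher from compound 1 to compound 4 (within the scatter) against 1-methyl-1-(trifluoromethyl)ethoxy and a number 14 percentage points higher from compound 2 to compound 4 (beyond the scatter) against (oxetan-3-yl)oxy, which repeats for a group with a ring what isopropylsulfanyl showed against the same two oxygen-linked groups. Nothing shown explains these numbers.

Going by these compounds, how an isopropoxy group on the carbonyl carbon would compare with isopropylsulfanyl remains open, and that comparison would separate the linking sulfur from the rest of the group. Also open, on these data alone, is whether a longer chain or an amine on the sulfur would stay in the range of compound 3 and compound 4.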